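Adding Chloro to Compound 3: Expected Step in Clearance

This account rests on a few compounds, and the source may have more. Where it says the series, first, only, none or still open, it means among the compounds named here.

Three compounds have so far been measured in an ADME assay on microsomes from liver (Mus musculus, strain NMRI) for metabolic stability, tested at 2.5 uM; on this read-out higher numbers stand for fast clearance and lower numbers for slow clearance:

compound 1, `Fc1cc(Cl)ccc1-c1ccc(Cn2nnc3ccccc32)nc1`, gives 1.6 mL/min/g
compound 2, `Fc1cc(Cl)ccc1-c1ccc(Cn2nnc3c(C(F)(F)F)cccc32)cn1`, gives 0.1 mL/min/g
compound 3, `Fc1cccc(Cn2nnc3c(Br)cccc32)c1`, gives 1.3 mL/min/g

Among these three numbers compound 3 stands second highest. Its nearest neighbour is compound 1, whose number is higher by an amount that lies within the usual scatter, so the two cannot be told apart. Compound 2 lies furthest away, with a number lower than that of compound 3 by a gap well beyond the scatter. For the measured compounds named here, no pair of the measured compounds differs in a single place, so none of these gaps can be tied to one structural change.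

Compound 4, `Fc1cc(Cn2nnc3c(Br)cccc32)ccc1Cl`, has not yet been measured. It differs from compound 3 in one place: chloro in place of hydrogen on an aromatic carbon. Going by the values given here, no measured pair shows this change on its own, so there is nothing to weigh it against directly. The expected step of a 1.3-fold lower number from compound 3 to compound 4 (0.11 log units; within the scatter) in this assay is therefore small, pointing slightly downward and not beyond the scatter. Compound 4 is estimated at 1 mL/min/g, with a range from 0.4 mL/min/g to 2.5 mL/min/g.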

Compound 4, intrinsic clearance in a liver preparation (reported as CLH), per the amount of preparation that the assay uses: 2.2 mL/min/g
Compound 4: middle estimate off by 2.2-fold (0.34 log units), on the low side; low and high end bracket the measured number.
By their numbers in this assay, from the lowest: compound 2; then compounds 3, 1 and 4 (each within the scatter of the next).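

In this assay, chloro in place of hydrogen on an aromatic carbon, ortho to a fluoro group and para to a large group, gives a 1.7-fold higher number from compound 3 to compound 4 (0.23 log units; within the scatter) and so provides the first change in a single place among these compounds. The earlier compounds shown here could not show what one substitution does, whereas this pair shows that adding this single chlorine at this position leaves compound 3 and compound 4 indistinguishable on this read-out, with no step beyond the scatter. The data offer no measured property of either compound that bears on this small step, so the result stands as an observation without an explanation.

From the compounds shown here alone, it remains open whether a different group at the same position, such as a methoxy group, a nitrile or an amine, would give a step beyond the scatter, or whether only the size of the entering group matters. It also remains open whether chloro in place of hydrogen would give a similarly small step on the cores of compound 1 and compound 2, where the same change has no matched partner among the compounds shown.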